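The compounds below may be only part of what the source reports. "The series", "measured", "known", "first", "only" and "open" are said of these compounds alone.

The measured compounds, each with its result in a functional assay on DU-145 cells (Homo sapiens) for cytotoxicity, read by MTT assay; a lower number here means a stronger inhibitor, a higher number a weaker inhibitor:

Compound 1 `CC(=O)OCCC(=O)O[C@H](CC=C(C)C)C1=CC(=O)c2c(O)ccc(O)c2C1=O`, 15700 nM
Compound 2 `COCCO[C@H](CC=C(C)C)C1=CC(=O)c2c(O)ccc(O)c2C1=O`, 43200 nM
Compound 3 `CC(C)=CC[C@@H](OC(=O)C1CCOC1)C1=CC(=O)c2c(O)ccc(O)c2C1=O`, 47500 nM

Compound 1 has the lowest number of the three; a 2.8-fold higher number from compound 1 to compound 2 (0.44 log units; beyond the scatter) and a 3.0-fold higher number from compound 1 to compound 3 (0.48 log units; beyond the scatter) are both beyond the scatter, while compound 2 and compound 3 lie within the scatter of each other. Compound 4 `CC(C)=CC[C@@H](OC(=O)C1CCCO1)C1=CC(=O)c2c(O)ccc(O)c2C1=O` differs from compound 1 by oxolan-2-yl in place of 2-acetoxyethyl on a carbonyl carbon. The step from compound 1 to compound 3 bears most directly on this change, since it also replaced the 2-acetoxyethyl on the carbonyl carbon with an oxolanyl group, and it raised the number modestly. A similar modest rise is therefore expected for compound 4, giving a 2.5-fold higher number from compound 1 to compound 4 (0.41 log units; beyond the scatter). Compound 4 is thus estimated at 40000 nM, with a range from 15000 nM to 100000 nM.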

Compound 4, half-maximal inhibitory concentration: 10500 nM
For compound 4 the middle estimate is 3.8-fold (0.58 log units) above the measured one; the whole stated range lies above it.
By their numbers in this assay, from the lowest: compounds 4 and 1 (each within the scatter of the next); then compounds 2 and 3 (each within the scatter of the next).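

In this assay, moving from oxolan-3-yl to oxolan-2-yl on the carbonyl carbon gave a 4.5-fold lower number from compound 3 to compound 4 (0.66 log units; beyond the scatter) and so showed that the two oxolanyl groups are not interchangeable at this position. The oxolan-2-yl ester stayed level with the 2-acetoxyethyl ester, with a 1.5-fold lower number from compound 1 to compound 4 (0.17 log units; within the scatter) and, against the 2-methoxyethyl ether, gave a 4.1-fold lower number from compound 2 to compound 4 (0.61 log units; beyond the scatter) as its result. No measurement available here accounts for these differences. Still open, on these data alone, is how an amine or a carboxylic acid on the same carbonyl carbon would compare with the oxolan-2-yl group.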